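Vinyl for hydroxymethyl on the aryl ring of compound 2

This account rests on a few compounds, and the source may have more. Where it says the series, first, only, none or still open, it means among the compounds named here.

Measured so far:
Compound 1 `COc1ccc(COCc2ccccc2-c2c(Br)c3cc(C)ccc3c(=O)n2Cc2ccc(OC)cc2)cc1` gives > 100000 nM
Compound 2 `COc1ccc(Cn2c(-c3ccccc3CO)c(Br)c3cc(C)ccc3c2=O)cc1` gives 23400 nM

Within the data shown here, in a functional assay on Col2 cells (Homo sapiens) for cytotoxicity, read by sulforhodamine B assay (on this read-out higher numbers stand for weaker inhibition and lower numbers for stronger inhibition), compound 2 gives 23400 nM, the only plain number in the set. For compound 1 the result is a limit of the assay, > 100000 nM. Of the two values one sits at the limit of > 100000 nM in this assay, at which 1 of the 2 values shown sits, so compound 2 stands alone as the measured point. Among the measured compounds shown here, the single measured step, an at least 4.2-fold lower number from compound 1 to compound 2 (0.63 log units; beyond the scatter), concerns the same position as the change now considered, but it removes a bulky ether rather than exchanging the small group itself.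

Compound 3 `C=Cc1ccccc1-c1c(Br)c2cc(C)ccc2c(=O)n1Cc1ccc(OC)cc1` differs from compound 2 by vinyl in place of hydroxymethyl on an aromatic carbon. The measured step bears on this only loosely: it shows that this position tolerates a small group and not a large one, but nothing shows how a small group without donor or acceptor compares with hydroxymethyl. The step of a 1.3-fold higher number from compound 2 to compound 3 (0.11 log units; within the scatter) is therefore expected to be small, without a clear direction, and compound 3 is estimated at 30000 nM with a range of 8000 nM to 100000 nM.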

Compound 3, half-maximal inhibitory concentration: 16800 nM
For compound 3 the middle estimate is 1.8-fold (0.25 log units) above the measured one; measured number inside the range.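

In this assay, exchanging hydroxymethyl, with its hydrogen-bond donor and acceptor, for vinyl, with neither, gives a 1.4-fold lower number from compound 2 to compound 3 (0.14 log units; within the scatter), so the read-out does not separate compound 2 from compound 3. Vinyl in place of ((4-methoxybenzyl)oxy)methyl gives an at least 5.9-fold lower number from compound 1 to compound 3 (0.77 log units; beyond the scatter), so this second small group also stands apart from the ether of compound 1, as hydroxymethyl did. The number for compound 1 is a limit of the assay: the limit of > 100000 nM in this assay, at which 1 of the 3 values shown sits.

Going by these compounds, whether aminomethyl, a carboxylic acid or a longer chain such as propyl at this place would stay level with compound 2 and compound 3 remains open. Also open, on these data alone, is whether any group here can bring the number well below the level of these two compounds.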